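Replacing the dihalophenyl amide in a quinazoline-linked acrylamide series

This account rests on a few compounds, and the source may have more. Where it says the series, first, only, none or still open, it means among the compounds named here.

Compound 1 `C=CC(=O)Nc1cccc(NC(=O)CSc2nc(Nc3ccccc3F)c3ccccc3n2)c1`: 6580 nM
Compound 2 `C=CC(=O)Nc1cccc(NC(=O)CSc2nc(Nc3cccc(Br)c3)c3ccccc3n2)c1`: 12100 nM
Compound 3 `C=CC(=O)Nc1cccc(NC(=O)CSc2nc(Nc3ccc(F)c(Cl)c3)c3ccccc3n2)c1`: > 50000 nM

Of the compounds shown here, three sharing one core have been tested in a functional assay on NCI-H1975 cells (Homo sapiens) for inhibition, read by MTT assay, with a stated time of 72 h; on this read-out lower numbers stand for stronger inhibition and higher numbers for weaker inhibition. Compound 1 gives 6580 nM and compound 2 gives 12100 nM; the two differ by a 1.8-fold higher number from compound 1 to compound 2 (0.26 log units; within the scatter). Compound 3 returns only a limit of the assay, > 50000 nM, so its position among the three is known only as being at or beyond that edge (the limit of > 50000 nM in this assay, at which 1 of the 3 values shown sits). Moving from either of the other two onto compound 3 is a loss: an at least 7.5-fold higher number from compound 1 to compound 3 (0.88 log units; beyond the scatter) and an at least 4.1-fold higher number from compound 2 to compound 3 (0.61 log units; beyond the scatter).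

Compound 4 `C=CC(=O)Nc1cccc(NC(=O)CSc2nc(Nc3ccc(Cl)cc3Cl)c3ccccc3n2)c1` has not yet been measured. It differs from compound 3 by 2,4-dichlorophenyl in place of 3-chloro-4-fluorophenyl on a nitrogen on an aromatic ring. Going by the values given here, no measured step starts from compound 3, so the only guidance is that each change of the aryl group on that nitrogen has so far moved this assay by a modest to large amount, and that the one compound bearing a 2-fluorophenyl, compound 1, sits lowest among the numbers. Compound 4 is therefore expected to come back below the limit, an improvement of an at least 2.5-fold lower number from compound 3 to compound 4 (0.39 log units; beyond the scatter), with an estimate of 20000 nM in this assay spanning 5000 nM to 60000 nM, while a result again at the limit remains quite possible.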

Compound 4, half-maximal inhibitory concentration: 5990 nM
Estimate against measurement, compound 4: 3.3-fold (0.52 log units) above; the range from low to high includes it.
By their numbers in this assay, from the lowest: compounds 4, 1 and 2 (each within the scatter of the next, the first and the last beyond it). At a limit, above all of these: compound 3.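

With the heavy-atom count unchanged, 2,4-dichlorophenyl in place of 3-chloro-4-fluorophenyl on this nitrogen brings the series back within the measurable range (an at least 8.3-fold lower number from compound 3 to compound 4 (0.92 log units; beyond the scatter)), so carrying two halogens on this ring does not by itself account for the result of compound 3. The new group also gives a modest gain over 3-bromophenyl (a 2.0-fold lower number from compound 2 to compound 4 (0.31 log units; beyond the scatter)), yet it cannot be told apart from 2-fluorophenyl (a 1.1-fold lower number from compound 1 to compound 4 (0.04 log units; within the scatter)). Compound 3 remains a limit, so the size of the first step is only a minimum: the limit of > 50000 nM in this assay, at which 1 of the 4 values shown sits.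

As far as these compounds go, whether an aryl group without halogen, such as a 4-methoxyphenyl or a pyridine ring, would hold these values on this nitrogen remains open. Also open, from the compounds shown here alone, is what an amine or a carboxylic acid on that ring would do.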